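The source may hold more compounds than are shown below. What is called first, only, known or untested is meant among the compounds shown, and "the series" means these compounds.

Measured in a functional assay on HepG2 cells (Homo sapiens) for antiproliferative activity, read by MTT assay, with a stated time of 48 h; a higher number here means a weaker inhibitor, a lower number a stronger inhibitor:
Compound 1 `COc1ccc(/C=C/c2cc(OC)cc(OC)c2/C=C/C(=O)c2cccc(Cl)c2)cc1`: 9.5 ug/mL
Compound 2 `COc1ccc(/C=C/c2cc(OC)cc(OC)c2/C=C/C(=O)c2ccc(N)cc2)cc1`: 7.5 ug/mL
Compound 3 `CCOc1ccc(C(=O)/C=C/c2c(/C=C/c3ccc(OC)cc3)cc(OC)cc2OC)cc1`: 8 ug/mL

Compound 3 cannot be separated from the other two compounds on these numbers. This is seen in a 1.2-fold lower number from compound 1 to compound 3 (0.07 log units; within the scatter) and in a 1.1-fold higher number from compound 2 to compound 3 (0.03 log units; within the scatter). The next compound, compound 4 `COc1ccc(/C=C/c2cc(OC)cc(OC)c2/C=C/C(=O)c2ccc(C)cc2C)cc1`, keeps the shared core and changes only the group on a carbonyl carbon: 2,4-dimethylphenyl in place of 4-ethoxyphenyl on a carbonyl carbon. In words, 2,4-dimethylphenyl stands in place of 4-ethoxyphenyl.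

All three measured steps change this same group, so all three bear on the comparison. They are a 1.3-fold lower number from compound 1 to compound 2 (0.10 log units; within the scatter), a 1.2-fold lower number from compound 1 to compound 3 (0.07 log units; within the scatter) and a 1.1-fold higher number from compound 2 to compound 3 (0.03 log units; within the scatter). Among the compounds with values here, none of them leaves the scatter, although no measured compound carries 2,4-dimethylphenyl, so the expectation is an extrapolation. No step beyond the scatter is therefore expected in this assay, and no direction can be favoured. The expected change is no change at the digits printed from compound 3 to compound 4 (within the scatter). For compound 4 the estimated value is 8 ug/mL, with an expected range from 4.5 ug/mL to 14 ug/mL.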

Compound 4, half-maximal inhibitory concentration: 0.9 ug/mL
The estimate for compound 4 lay 8.9-fold (0.95 log units) above the measured number, and the stated range ends above it.
By their numbers in this assay, from the lowest: compound 4; then compounds 2, 3 and 1 (each within the scatter of the next).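

The carbonyl carbon had looked indifferent to the change among 3-chlorophenyl, 4-aminophenyl and 4-ethoxyphenyl, but in this assay 2,4-dimethylphenyl separates from all three, giving an 8.9-fold lower number from compound 3 to compound 4 (0.95 log units; beyond the scatter) and an 8.3-fold lower number from compound 2 to compound 4 (0.92 log units; beyond the scatter) as well as an 11-fold lower number from compound 1 to compound 4 (1.02 log units; beyond the scatter) in a single change of this group. The aryl group at this place can therefore move the number substantially, and compound 4 stands apart from the other three compounds. Nothing available explains this drop.

Within the data shown here, with only one compound carrying 2,4-dimethylphenyl, it remains open whether both methyl groups are needed or whether one would suffice. On these data alone, how an unsubstituted phenyl, or a phenyl carrying a carboxylic acid, would behave at this place also remains open.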